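Amino to dimethylamino on the shared core

This account rests on a few compounds, and the source may have more. Where it says the series, first, only, none or still open, it means among the compounds named here.

Values in a physicochemical assay for solubility, measured as kinetic solubility, at pH 6.5 (on this read-out higher numbers stand for higher solubility and lower numbers for lower solubility), are as follows.
- compound 1 (`Fc1ccc(-c2ccc3nnc(Cc4ccc5ncccc5c4)n3n2)cc1F`) gives 11500 nM
- compound 2 (`C[C@@H](c1ccc2ncccc2c1)c1nnc2ccc(-c3cccc(C#N)c3)nn12`) gives 32500 nM
- compound 3 (`Nc1ccc2nnc(Cc3ccc4ncccc4c3)n2n1`) gives 453000 nM

Compound 3 stands highest of the three, with compound 2 nearest and compound 1 furthest. Compound 4 (`CN(C)c1ccc2nnc(Cc3ccc4ncccc4c3)n2n1`) has dimethylamino in place of amino on an aromatic carbon, with nothing else changed. Among the measured compounds shown here, the only measured step at this place is a 39-fold higher number from compound 1 to compound 3 (1.60 log units; beyond the scatter) and it is large, but it involves 3,4-difluorophenyl, so it gives only an outer size. The expected step is a 2.5-fold lower number from compound 3 to compound 4 (0.40 log units; beyond the scatter) and would be a moderate one toward a lower number. Compound 4 is estimated at 180000 nM (50000 nM to 500000 nM).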

Compound 4, solubility: 134000 nM
Estimate against measurement, compound 4: 1.3-fold (0.13 log units) above, and the stated range covers the measured number.
By their numbers in this assay, from the lowest: compound 1; then compound 2; then compound 4; then compound 3.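

At this position on the shared core, this assay now has a second small amine to compare: dimethylamino, with no hydrogen-bond donor, in place of amino gives a 3.4-fold lower number from compound 3 to compound 4 (0.53 log units; beyond the scatter) in this series. Dimethylamino still keeps much of the gain over the 3,4-difluorophenyl group, with a 12-fold higher number from compound 1 to compound 4 (1.07 log units; beyond the scatter), so that gain is not confined to amino. No supporting measurement bears on the difference between these groups. Open, going by these compounds, is where methylamino, a morpholine ring or a longer chain on the nitrogen would fall relative to compound 3 and compound 4.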